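A few compounds are considered here, and "the series" means these few. Any claim that something is new, unique, unknown or untested is made for them only; others in the source may bear on it.

Measured compounds:
compound 1 `CCCCCCCCCCCCCC[C@H](O)[C@H](CO[Si](c1ccccc1)(c1ccccc1)C(C)(C)C)NC(=O)OC(C)(C)C` — 10.4%
compound 2 `CCCCCCCCCCCCCC[C@H](OCOC)[C@H](CO[Si](c1ccccc1)(c1ccccc1)C(C)(C)C)NC(=O)OC(C)(C)C` — -14.6%
compound 3 `CCCCCCCCCCCCCC[C@H](OCOC)[C@H](CN(CC)CC)NC(=O)OC(C)(C)C` — 46.2%

In a functional assay on DLD-1 cells (Homo sapiens) for antiproliferative activity, read by sulforhodamine B assay, with a stated time of 48 h, tested at 10 uM (on this read-out lower numbers stand for less inhibition and higher numbers for more inhibition at the one concentration tested (going by the name of the read-out)), compound 2 gives the lowest number, compound 1 a higher one, and compound 3 the highest of the three. The step of a number 25 percentage points higher from compound 2 to compound 1 (beyond the scatter) is a modest one and is made by the change (hydrogen in place of methoxymethyl on an oxygen on a saturated carbon). Compound 3 and compound 2 share the same change at the side chain but differ elsewhere; the difference between the two cores is not broken down here.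

Compound 4 `CCCCCCCCCCCCCC[C@H](O)[C@H](CN(CC)CC)NC(=O)OC(C)(C)C` has not yet been measured in this assay. It differs from compound 3 by hydrogen in place of methoxymethyl on an oxygen on a saturated carbon, the same change that takes compound 2 to compound 1. Since that step was a number 25 percentage points higher from compound 2 to compound 1 (beyond the scatter), a step of similar size is expected here, a number 21.8 percentage points higher from compound 3 to compound 4 (beyond the scatter), although the cores differ and the transfer is uncertain. Compound 4 is therefore estimated to give about 68% in this assay, expected between 45% and 90%.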

Compound 4, a percentage reported as inhibition, at one concentration (the size of the read-out at that concentration, not a potency): 14.7%
Beside the measured number, compound 4's estimate is 53.3 percentage points above it, and the stated range ends above it.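

In this assay, hydrogen in place of methoxymethyl on the oxygen gives a number 31.5 percentage points lower from compound 3 to compound 4 (beyond the scatter), so the change does not carry over from one core to another in this series, and its direction reverses between the two pairs: the same change on two cores in this assay, a number 25 percentage points higher (beyond the scatter) from compound 2 to compound 1 and a number 31.5 percentage points lower (beyond the scatter) from compound 3 to compound 4, 56.5 percentage points apart, beyond the scatter of two such steps. This shows that the outcome of the change depends on the core that carries it. Within the data shown here, with only two pairs, it does not show which part of the cores decides the outcome, or what the change would do on a third core.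

The compounds shown leave open how a methyl or an acetyl group on that oxygen would compare with hydrogen and methoxymethyl. They also leave open whether a primary amine on the core, or a shorter chain, would alter the result of the same change.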